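Swapping a Cyclopropyl for a Chloroethyl Chain

This account rests on a few compounds, and the source may have more. Where it says the series, first, only, none or still open, it means among the compounds named here.

Of the compounds shown here, three built on one shared core have been measured in a functional assay on KYSE-450 cells (Homo sapiens) for inhibition, read by MTT assay, with a stated time of 48 h; a lower number here means a stronger inhibitor, a higher number a weaker inhibitor. Compound 1 `C/C=C/C(=O)N(Cc1cccc(O)c1)c1cc(OC)c(OC)c(OC)c1` gives 14700 nM. Compound 3 `COc1ccc(CNc2cc(OC)c(OC)c(OC)c2)cc1Br` gives 39800 nM. Compound 2 `COc1ccc(CN(C(=O)C2CC2)c2cc(OC)c(OC)c(OC)c2)cc1O` gives 80 nM, the lowest of the three numbers: compound 1 stands a long way above it, and compound 3 further still, both gaps well beyond the scatter of repeated measurements. No two of these three compounds differ in only one place, so no single change can be tied to a step among them.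

Compound 4 `COc1ccc(CN(C(=O)CCCl)c2cc(OC)c(OC)c(OC)c2)cc1O` has not yet been measured. It differs from compound 2 in one place: 2-chloroethyl in place of cyclopropyl on a carbonyl carbon. Both groups are small and sit on the carbonyl carbon, so the rest of the molecule, including the part that makes compound 2 stand out, is kept as it is. Among the compounds with values here, nothing among the measured compounds shows what such a swap does here, so the expectation rests on the smallness of the change alone. The step that this estimate means, a 1.9-fold higher number from compound 2 to compound 4 (0.27 log units; within the scatter), is expected to be a slight weakening, hardly beyond the scatter. Compound 4 is estimated at 150 nM, with a range from 40 nM to 600 nM.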

Compound 4, half-maximal inhibitory concentration: 110 nM
Estimate against measurement, compound 4: 1.4-fold (0.13 log units) above; measured number inside the range.
By their numbers in this assay, from the lowest: compounds 2 and 4 (each within the scatter of the next); then compound 1; then compound 3.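

In this assay, 2-chloroethyl in place of cyclopropyl on a carbonyl carbon gives a 1.4-fold higher number from compound 2 to compound 4 (0.14 log units; within the scatter), so the two compounds cannot be told apart in this assay. Within the data shown here, this pair gives the first direct reading at this position, which the earlier compounds could not provide, as none of them differed from another in only one place. It shows that, on this core, a number of this size does not depend on the three-membered ring of carbon: an open chain with no ring, carrying a chlorine, reads the same, although no measurement at hand tells what either group does in these cells.

This single swap removes the ring and brings in the chlorine together, so the pair cannot show what each of these two changes does alone, and a plain ethyl group in the same place would separate them. How much variety this position accepts also remains open, since only two groups of equal heavy-atom count are shown there, and a longer chain, an amine or a carboxylic acid on the carbonyl carbon could read quite differently.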